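Capping a Phenol: Hydroxy to Methoxy in a Urea Series

The compounds below may be only part of what the source reports. "The series", "measured", "known", "first", "only" and "open" are said of these compounds alone.

For the measured compounds named here, compound 1 `O=C(Nc1cccc(-n2cc(-c3ccncc3)c(-c3cc(O)cc(Cl)c3)n2)c1)Nc1ccc(Cl)c(C(F)(F)F)c1` is one of two compounds measured in a functional assay on HCT-15 cells (Homo sapiens) for inhibition, read by sulforhodamine B assay, with a stated time of 48 h, tested at 1 uM (a lower number here means a stronger effect, a higher number a weaker effect of the compound at the concentration tested), where compound 1 gives 90%, the higher of the two numbers. Compound 2 `O=C(Nc1cccc(-n2cc(-c3ccncc3)c(-c3cc(O)cc(Cl)c3)n2)c1)Nc1ccc(Cl)c(Cl)c1` gives 75%, and a number 15 percentage points lower from compound 1 to compound 2 (beyond the scatter). Compound 3 `COc1cc(Cl)cc(-c2nn(-c3cccc(NC(=O)Nc4ccc(Cl)c(C(F)(F)F)c4)c3)cc2-c2ccncc2)c1` differs from compound 1 by methyl in place of hydrogen on an oxygen on an aromatic ring. Going by the values given here, no measured step involves this change; the only step known, from compound 1 to compound 2, alters a different part of the molecule and gives no guide here. Compound 3 is therefore expected to show a number 2 percentage points lower from compound 1 to compound 3 (within the scatter), meaning nothing beyond the scatter. The estimate for compound 3 is 88%, between 70% and 100%.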

Compound 3, a percentage reported as activity, at one concentration (the size of the read-out at that concentration, not a potency): 35%
Compound 3: the middle estimate sits 53 percentage points above what was measured, outside the stated range (below it).
By their numbers in this assay, from the lowest: compound 3; then compound 2; then compound 1.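

Capping the hydroxy as methoxy in this assay gives a number 55 percentage points lower from compound 1 to compound 3 (beyond the scatter), and a lower number here means a stronger effect. For the compounds shown here, the earlier pair changed a different part of the molecule, so this is the first sign that the oxygen on the 3-chloro-5-hydroxyphenyl group is a sensitive position, where a single methyl makes a large difference. No supporting measurement bears on why the step is so large.

From the compounds shown here alone, whether the same step would hold alongside the chloro of compound 2 remains open. Also open, going by these compounds, is how an ethoxy group or an amine at this position would compare.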